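The source may report more compounds than this note shows. Statements on the series, on what has been measured and on what is new or still open speak of the compounds shown alone.

Three analogues of a shared core have been run in a functional assay on HCT-116 cells (Homo sapiens) for cytotoxicity, read by MTT assay, with a stated time of 72 h; on this read-out lower numbers stand for stronger inhibition and higher numbers for weaker inhibition. Compound 1 `COc1ccc(Nc2nc3ccccc3nc2S(=O)(=O)c2ccc(OC)cc2)cc1` gives 29100 nM. Compound 2 `COc1ccc(S(=O)(=O)c2nc3ccccc3nc2Nc2cc(OC)cc(OC)c2)cc1` gives 13400 nM; the step of a 2.2-fold lower number from compound 1 to compound 2 (0.34 log units; beyond the scatter) corresponds to 3,5-dimethoxyphenyl in place of 4-methoxyphenyl on a nitrogen on an aromatic ring. Compound 3 `COc1ccc(Nc2nc3ccccc3nc2S(=O)(=O)c2ccc(Br)cc2)cc1` gives 3400 nM, the lowest number of the three, reached through an 8.6-fold lower number from compound 1 to compound 3 (0.93 log units; beyond the scatter), the change there being (bromo in place of methoxy on an aromatic carbon).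

Compound 4 `COc1cc(Nc2nc3ccccc3nc2S(=O)(=O)c2ccc(Br)cc2)cc(OC)c1` has not yet been measured in this assay. It differs from compound 3 by 3,5-dimethoxyphenyl in place of 4-methoxyphenyl on a nitrogen on an aromatic ring. This is the same change that was made from compound 1 to compound 2, with the place described in identical words for both pairs, and there it gave a 2.2-fold lower number from compound 1 to compound 2 (0.34 log units; beyond the scatter). The cores of the two pairs differ by bromo in place of methoxy on an aromatic carbon. For the measured compounds named here, no other pair shows this exchange on the bromo-bearing core, so the expectation rests on a single earlier step and is held loosely.

The expected step is a 2.1-fold lower number from compound 3 to compound 4 (0.33 log units; beyond the scatter), taken directly from a 2.2-fold lower number from compound 1 to compound 2 (0.34 log units; beyond the scatter) on the other core. Compound 4 is accordingly expected near 1600 nM, with a plausible range from 700 nM to 3600 nM.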

Compound 4, half-maximal inhibitory concentration: > 50000 nM
Compound 4 ended at the assay's limit; the forecaster's own chance of this, stated with the estimate: 2%; middle value at least 31-fold (1.49 log units) from the limit.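

On the core of compound 3, the exchange of 4-methoxyphenyl for 3,5-dimethoxyphenyl on the nitrogen (an at least 14-fold higher number from compound 3 to compound 4 (1.16 log units; beyond the scatter)) runs opposite to its earlier direction in this assay, so this exchange does not carry from one core to the other: the same change on two cores in this assay, a 2.2-fold lower number (0.34 log units; beyond the scatter) from compound 1 to compound 2 and an at least 14-fold higher number (1.16 log units; beyond the scatter) from compound 3 to compound 4, at least 31-fold (1.50 log units) apart, beyond the scatter of two such steps

The exchange of methoxy for bromo likewise differs with the group on the nitrogen (an at least 3.7-fold higher number from compound 2 to compound 4 (0.57 log units; beyond the scatter)), and its earlier step does not carry over either: the same change on two cores in this assay, an 8.6-fold lower number (0.93 log units; beyond the scatter) from compound 1 to compound 3 and an at least 3.7-fold higher number (0.57 log units; beyond the scatter) from compound 2 to compound 4, at least 31-fold (1.50 log units) apart, beyond the scatter of two such steps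

For the compounds shown here, compound 4 stands at (> 50000 nM), a limit of the assay and not a number, so the notes fix neither the true size of these steps nor any general rule, with only one pair on each core.

Still open, on these data alone, is whether the same reversal appears when a chloro, a nitrile or a carboxylic acid takes the place of the bromo. Also open, as far as these compounds go, is how the series responds when an amine or a longer alkyl chain replaces the methoxy-bearing phenyl groups on the nitrogen.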